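The source may report more compounds than this note shows. Statements on the series, on what has been measured and on what is new or still open speak of the compounds shown alone.

Three compounds of the series have numbers in a functional assay on CHO cells with adenosine receptor A1 (Homo sapiens) as the target, read by cAMP accumulation and immunoassay, with a stated time of 6 min, tested at 0.1 uM; on this read-out lower numbers stand for a stronger effect and higher numbers for a weaker effect at the one concentration tested. Compound 1 `Nc1scc(CN2CCN(c3ccc(Cl)cc3Cl)CC2)c1C(=O)c1ccc(Cl)cc1` gives -11%, compound 2 `Nc1scc(CN2CCN(c3ccc(F)c(F)c3)CC2)c1C(=O)c1ccc(Cl)cc1` gives -34%, and compound 3 `Nc1scc(CN2CCN(c3cc(F)cc(F)c3)CC2)c1C(=O)c1ccc(Cl)cc1` gives -5%. Compound 3 stands highest of the three; the two steps leading up to it are a number 6 percentage points higher from compound 1 to compound 3 (within the scatter) and a number 29 percentage points higher from compound 2 to compound 3 (beyond the scatter).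

Compound 4 `Nc1scc(CN2CCN(c3ccc(Cl)c(Cl)c3)CC2)c1C(=O)c1ccc(Cl)cc1` is not yet measured. The change is 3,4-dichlorophenyl in place of 3,5-difluorophenyl on an amine nitrogen in a ring. Going by the values given here, two steps bear on it: the move from 3,4-difluorophenyl to 3,5-difluorophenyl gave a number 29 percentage points higher from compound 2 to compound 3 (beyond the scatter), while swapping chlorines for fluorines gave only a number 6 percentage points higher from compound 1 to compound 3 (within the scatter). Returning to the 3,4-pattern is therefore expected to lower the number modestly, by about a number 20 percentage points lower from compound 3 to compound 4 (beyond the scatter). Compound 4 is estimated at -25%, within -45% to -5%.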

Compound 4, a percentage reported as activity, at one concentration (the size of the read-out at that concentration, not a potency): -13%
For compound 4 the middle estimate is 12 percentage points below the measured one; the measured number falls inside the stated range.
By their numbers in this assay, from the lowest: compound 2; then compounds 4, 1 and 3 (each within the scatter of the next).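

In this assay the 3,4-pattern alone does not carry the low number of compound 2, since 3,4-dichlorophenyl in place of 3,4-difluorophenyl gives a number 21 percentage points higher from compound 2 to compound 4 (beyond the scatter) and so separates the two halogens on the same pattern. With a number 8 percentage points lower from compound 3 to compound 4 (within the scatter) and a number 2 percentage points lower from compound 1 to compound 4 (within the scatter) as the other two steps, compound 4 cannot be told apart from either, and compound 2 stands alone at this position. Nothing on hand gives a reason for this.

From the compounds shown here alone, whether a phenyl carrying one fluorine, one chlorine or a methoxy group falls with compound 2 or with the other three remains open.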